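From Chloro to Fluoro on a Shared Core

The compounds below may be only part of what the source reports. "The series", "measured", "known", "first", "only" and "open" are said of these compounds alone.

In a functional assay on HepG2 cells (Homo sapiens) for antiproliferative activity, read by MTT assay, with a stated time of 72 h (on this read-out higher numbers stand for weaker inhibition and lower numbers for stronger inhibition), compound 1 `COc1cc(CCc2ccccc2)cc(OC)c1O` gives 7830 nM, compound 2 `COc1ccc(CCc2ccc([N+](=O)[O-])cc2)cc1OC` gives 1600 nM and compound 3 `COc1cc(CCc2ccccc2Cl)cc(OC)c1O` gives 2190 nM. Compound 3 therefore cannot be told apart from compound 2, and it stands clearly below compound 1. Compound 4 `COc1cc(CCc2ccccc2F)cc(OC)c1O` has fluoro in place of chloro on an aromatic carbon. Going by the values given here, the only measured step that bears on this is a 3.6-fold lower number from compound 1 to compound 3 (0.55 log units; beyond the scatter), with chloro in place of hydrogen on an aromatic carbon. Among the compounds with values here, no fluoro compound has been measured, so fluoro is assumed to keep only part of that drop. In this assay, the expected change is small and upward: a 1.6-fold higher number from compound 3 to compound 4 (0.20 log units; within the scatter). For compound 4, the estimated value is 3500 nM, within a range of 1500 nM to 8000 nM.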

Compound 4, half-maximal inhibitory concentration: 1030 nM
For compound 4 the middle estimate is 3.4-fold (0.53 log units) above the measured one, and the stated range ends above it.
By their numbers in this assay, from the lowest: compounds 4, 2 and 3 (each within the scatter of the next, the first and the last beyond it); then compound 1.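

In this position, ortho to a large group, the two halogens are not interchangeable: fluoro in place of chloro gives a 2.1-fold lower number from compound 3 to compound 4 (0.33 log units; beyond the scatter) in this assay, a step just beyond the usual scatter. Fluoro in place of hydrogen gives a 7.6-fold lower number from compound 1 to compound 4 (0.88 log units; beyond the scatter) in this assay, so the drop seen earlier with chloro grows larger with fluoro. Nothing measured here explains this difference between fluoro and chloro.

From the compounds shown here alone, whether bromo or an amine in the same place would give a lower or higher number stays open, and so does whether fluoro would have the same effect elsewhere on that ring.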